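Quinolinyl for Hydroxypiperidinyl: Solubility Outlook for Compound 4

The source may report more compounds than this note shows. Statements on the series, on what has been measured and on what is new or still open speak of the compounds shown alone.

Compound 1 `OCCC1CCN(c2nccnc2OC2CN(c3ccc4ccccc4n3)C2)CC1`, compound 2 `OC1CCN(c2nccnc2OC2CN(c3ccc4ccccc4n3)C2)CC1` and compound 3 `OCC1CCN(c2nccnc2OC2CN(c3ccc4ccccc4n3)C2)C1` share one core and differ only in the group on a single aromatic carbon. In a physicochemical assay for solubility, in phosphate buffer, at pH 7.4 (a lower number here means a less soluble compound, a higher number a more soluble compound), compound 1 gives 84000 nM, compound 2 gives 99000 nM and compound 3 gives 167000 nM. Compound 2 stands second highest of the three numbers, and every pair lies within the scatter: a 1.2-fold higher number from compound 1 to compound 2 (0.07 log units; within the scatter), a 1.7-fold higher number from compound 2 to compound 3 (0.23 log units; within the scatter) and a 2.0-fold higher number from compound 1 to compound 3 (0.30 log units; within the scatter).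

Compound 4 `c1ccc2ncc(-c3nccnc3OC3CN(c4ccc5ccccc5n4)C3)cc2c1` has no number yet in this assay. From compound 2 the change is quinolin-3-yl in place of 4-hydroxypiperidin-1-yl on an aromatic carbon. The two measured steps that touch compound 2 each exchange one hydroxy-bearing saturated ring for another and stay within the scatter; neither removes the hydrogen-bond donor nor brings in aromatic rings, so they give no direct guide to this step. The change itself is much larger than any step measured, and compound 4 is expected to give a clearly lower number, a 17-fold lower number from compound 2 to compound 4 (1.22 log units; beyond the scatter). The estimate for compound 4 in this assay is 6000 nM, with a range from 800 nM to 40000 nM.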

Compound 4, solubility: < 1000 nM
Compound 4 ended at the assay's limit (the forecaster's own chance of this, stated with the estimate: 15%); at least 6.0-fold (0.77 log units) between middle value and limit.
By their numbers in this assay, from the lowest: compounds 1, 2 and 3 (each within the scatter of the next). At a limit, below all of these: compound 4.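

In this assay compound 4 stands at a limit of the assay and not at a number: the limit of < 1000 nM in this assay, at which 1 of the 4 values shown sits. Quinolin-3-yl on this aromatic carbon, next to the ring nitrogen, gives the only steps in the set that lie beyond the scatter: an at least 99-fold lower number from compound 2 to compound 4 (1.99 log units; beyond the scatter), an at least 160-fold lower number from compound 3 to compound 4 (2.22 log units; beyond the scatter) and an at least 84-fold lower number from compound 1 to compound 4 (1.92 log units; beyond the scatter). The exchanges among 4-hydroxypiperidin-1-yl, 3-(hydroxymethyl)pyrrolidin-1-yl and 4-(2-hydroxyethyl)piperidin-1-yl all stay within the scatter, so this position shows a large difference only with quinolin-3-yl, and each of these steps is a minimum.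

The compounds shown leave open how far the step follows the loss of the hydroxy and how far the entry of the two aromatic rings. A piperidin-1-yl without the hydroxy and a quinolin-3-yl carrying an amine would help separate the two.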